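Trading a methyl for an ethoxy on the pendant ring

A few compounds are considered here, and "the series" means these few. Any claim that something is new, unique, unknown or untested is made for them only; others in the source may bear on it.

Of the compounds shown here, three sharing one core have been tested in a functional assay on HeLa cells (Homo sapiens) for antiproliferative activity, read by MTT assay, with a stated time of 72 h; a lower number here means a stronger inhibitor, a higher number a weaker inhibitor. Compound 1 `COc1ccccc1-c1ncnn1-c1cc(OC)c(OC)c(OC)c1` gives > 10000 nM, which is a limit of the assay rather than a number. Within the data shown here, compound 2 `COc1cc(-n2ncnc2-c2ccc(C)cc2)cc(OC)c1OC` gives 250 nM in this assay, the only actual number among the three. Compound 3 `COc1cc(-n2ncnc2-c2cccc(Cl)c2)cc(OC)c1OC` gives > 10000 nM, again a limit of the assay. Compound 2 therefore stands alone as the one measurable inhibitor, with the other two sitting at the limit of > 10000 nM in this assay, at which 2 of the 3 values shown sit.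

Compound 4 `CCOc1ccc(-c2ncnn2-c2cc(OC)c(OC)c(OC)c2)cc1` differs from compound 2 only on the pendant ring: ethoxy in place of methyl on an aromatic carbon. Both measured steps that touch this ring were large: an at least 40-fold lower number from compound 1 to compound 2 (1.60 log units; beyond the scatter) and an at least 40-fold higher number from compound 2 to compound 3 (1.60 log units; beyond the scatter). Changes on this ring thus swing the number strongly, yet neither step tells which way an ethoxy would move it. A moderate weakening is expected for compound 4, so a 2.4-fold higher number from compound 2 to compound 4 (0.38 log units; beyond the scatter) is estimated. Compound 4 is expected to give about 600 nM in this assay, between 150 nM and 5000 nM.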

Compound 4, half-maximal inhibitory concentration: 15 nM
Beside the measured number, compound 4's estimate is 40-fold (1.60 log units) above it, outside the stated range (below it).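

In this assay, among these compounds, the change from methyl to ethoxy gives a 17-fold lower number from compound 2 to compound 4 (1.22 log units; beyond the scatter) and this is the first step on the pendant ring that can be read between two actual numbers rather than against a limit. It shows that this place, para to a large group, accepts more than a methyl: ethoxy brings 3 heavy atoms where methyl has 1, adds a hydrogen-bond acceptor, and still gives the lower number. Nothing measured here accounts for that gain.

The compounds shown do not separate the effect of the oxygen from that of the added chain length. From the compounds shown here alone, how a methoxy, a propoxy chain or an amine at the same place would compare with ethoxy remains open.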